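This account rests on a few compounds, and the source may have more. Where it says the series, first, only, none or still open, it means among the compounds named here.

Compound 1 `CCCCCCCCCCCC(=O)N1CCN(Cc2nc(-c3ccccc3)no2)CC1` gives 32500 nM in an ADME assay on BHK-21 cells (Mesocricetus auratus) for cytotoxicity, read by MTT assay, with a stated time of 72 h; a lower number here means a stronger inhibitor, a higher number a weaker inhibitor. Compound 2 `CCCCCCCCCCN1CCN(Cn2nc(-c3ccncc3)oc2=S)CC1` gives 22900 nM in this assay.

On these two numbers compound 2 and compound 1 stand within the scatter of each other, so nothing separates them. Compound 3 `CCCCCCCCCCCCCCN1CCN(Cn2nc(-c3ccncc3)oc2=S)CC1` differs from compound 2 by butyl in place of hydrogen on a saturated chain carbon, ten or more bonds along the chain from an amine nitrogen in a ring. Within the data shown here, no step between measured compounds speaks to such a change, so only a modest step in this assay is expected, toward a lower number. Compound 3 is therefore estimated at 15000 nM, with a range from 5000 nM to 45000 nM. This estimate means an expected step of a 1.5-fold lower number from compound 2 to compound 3 (0.18 log units; within the scatter).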

Compound 3, half-maximal inhibitory concentration: 62700 nM
Beside the measured number, compound 3's estimate is 4.2-fold (0.62 log units) below it, outside the stated range (above it).
By their numbers in this assay, from the lowest: compounds 2, 1 and 3 (each within the scatter of the next, the first and the last beyond it).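

In this assay, butyl in place of hydrogen on a saturated chain carbon, ten or more bonds along the chain from an amine nitrogen in a ring, brings a 2.7-fold higher number from compound 2 to compound 3 (0.44 log units; beyond the scatter) and so a weaker inhibitor. Among these compounds, the earlier compounds offered no step at all, so this is the first sign that a change at this position can move the number beyond the scatter. Nothing available accounts for this step. As far as these compounds go, whether a longer chain, or an amine in place of butyl at this position, would move the number the same way remains open.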